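Sulfonamide series at the limit; one further analogue awaited

This account rests on a few compounds, and the source may have more. Where it says the series, first, only, none or still open, it means among the compounds named here.

compound 1 `O=S(=O)(Nc1ccc2oc(-c3ccccc3)nc2c1)c1ccccc1O`: > 63000 nM
compound 2 `O=S(=O)(Nc1ccc2oc(-c3ccccc3)nc2c1)c1ccc(F)c(C(F)(F)F)c1`: > 63000 nM
compound 3 `O=S(=O)(Nc1ccc(-c2nc3ccccc3o2)cc1)c1ccccc1F`: > 63000 nM

In an assay on isolated protein for inhibition of malate dehydrogenase, mitochondrial (Sus scrofa), with stated times of 45 min and 30 min (a higher number here means a weaker inhibitor, a lower number a stronger inhibitor), compound 1 gives only a limit, > 63000 nM. Compound 2 likewise stops at a limit, > 63000 nM. Compound 3 also stops at a limit, > 63000 nM. Hence (the limit of > 63000 nM in this assay, at which 3 of the 3 values shown sit); compound 1 therefore has no number of its own, and no measured step between the three can be drawn.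

Compound 4 `CCc1ccc(S(=O)(=O)Nc2ccc3oc(-c4ccccc4)nc3c2)cc1` is to be measured in this assay. It differs from compound 1 by 4-ethylphenyl in place of 2-hydroxyphenyl on a sulfonyl sulfur. With every neighbour at the limit, no change beyond the scatter is expected; the step that the limit leaves unreadable from compound 1 to compound 4 is an estimate only. Compound 4 is expected to give around 80000 nM, within 30000 nM to 200000 nM, most likely again as a limit.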

Compound 4, half-maximal inhibitory concentration: > 63000 nM
Compound 4: only a limit was reported (the forecaster's own chance of this, stated with the estimate: 75%); the middle value lies beyond the limit too.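

In this assay, among these compounds, compound 1 and compound 4 both stop at a limit, so no step between them can be read: the limit of > 63000 nM in this assay, at which 4 of the 4 values shown sit. In this assay the compounds shown leave open whether any group on the sulfonyl sulfur gives a readable value.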